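This account rests on a few compounds, and the source may have more. Where it says the series, first, only, none or still open, it means among the compounds named here.

Compound 1, `Fc1ccc2ncc(-c3nn[nH]n3)cc2c1`: in a functional assay on the whole organism (strain Sprague-Dawley) for inhibition, with Rattus norvegicus as the target (on this read-out higher numbers stand for an effect only at larger amounts of compound and lower numbers for an effect already at smaller amounts), compound 1 gives 50 mg/kg.
Compound 2, `CCc1cccc2c(=O)c(-c3nn[nH]n3)c[nH]c12`: in this assay compound 2 gives > 25 mg/kg, which is a limit of the assay and not a number.

Among the values shown, compound 1 holds the only real number in this assay; the other entry is the limit of > 25 mg/kg in this assay, at which 1 of the 2 values shown sits, so compound 1 cannot be ranked against compound 2 in either direction. Among the compounds with values here, no step between two measured compounds is available, and the two compounds share no single point of difference.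

Compound 3, `CCCCc1ccc2ncc(-c3nn[nH]n3)cc2c1`, is the compound not yet measured. Relative to compound 1 its change is butyl in place of fluoro on an aromatic carbon. Within the data shown here, there is no measured precedent for exchanging fluoro for butyl in this set, so the size of the step can only be expected, not inferred: the step is expected to be no change at the digits printed from compound 1 to compound 3 (within the scatter), with no direction favoured beyond the usual scatter. On that basis compound 3 is expected to give about 50 mg/kg in this assay, in a range estimated from 12 mg/kg to 200 mg/kg, with a fair chance that only a limit is reported.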

Compound 3, minimum effective dose: > 25 mg/kg
Compound 3 ended at the assay's limit; the forecaster's own chance of this, stated with the estimate: 40%; the middle value lies beyond the limit too.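

In this assay compound 3 gives > 25 mg/kg, which is a limit of the assay and not a number, so no step can be read between compound 1 and compound 3. The compounds shown leave open how butyl in place of fluoro on an aromatic carbon alters the minimum effective dose, and most values offer no number: the limit of > 25 mg/kg in this assay, at which 2 of the 3 values shown sit.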